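Estimating Cytotoxicity for an Iodinated Analogue of Compound 2

This account rests on a few compounds, and the source may have more. Where it says the series, first, only, none or still open, it means among the compounds named here.

In an ADME assay on HOS cells (Homo sapiens) for cytotoxicity (a lower number here means a stronger inhibitor, a higher number a weaker inhibitor), compound 2 (`O=C1c2ccc(O)c(O)c2C(=O)N1Cc1ccc(F)cc1`) has no single number to stand on ("not determined" (no result reported)). The same is true of compound 1 (`O=C1c2ccc(O)c(O)c2C(=O)N1Cc1ccccc1` with "not determined" (no result reported)). Only compound 3 (`O=C1c2c(ccc(O)c2O)CN1Cc1cccc(Br)c1`) gives a number (7240 nM), and its core differs from that of compound 2.

Compound 4 (`O=C1c2ccc(O)c(O)c2C(=O)N1Cc1cccc(I)c1`) has yet to be measured. The structural change is 3-iodophenyl in place of 4-fluorophenyl on a saturated chain carbon bound to an amide-type nitrogen in a ring and puts 3-iodophenyl in place of 4-fluorophenyl on a saturated chain carbon bound to an amide-type nitrogen in a ring. Within the data shown here, with no measured step to draw on, neither the size nor the direction of this step can be read from the data, so no step beyond the scatter is expected in this assay. Among the measured compounds shown here, the only anchor is compound 3 (7240 nM), which also carries a halogen on its phenyl group, so the expectation stays close to that value, with a wide margin. The expected value for compound 4 is 10000 nM (estimated range 3000 nM to 35000 nM).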

Compound 4, half-maximal inhibitory concentration: 12000 nM
Compound 4: middle estimate off by 1.2-fold (0.08 log units), on the low side; the measured number falls inside the stated range.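

No step can be read from compound 2 to compound 4 in this assay: compound 2 has no single number there. The compounds shown leave open how far, and in which direction, 3-iodophenyl in place of 4-fluorophenyl moves the value. Nothing available explains the result of compound 4.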